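A few compounds are considered here, and "the series" means these few. Any claim that something is new, unique, unknown or untested is made for them only; others in the source may bear on it.

In an assay for inhibition of beta-glucuronidase (Bos taurus), read by spectrophotometry, with a stated time of 30 min (a higher number here means a weaker inhibitor, a lower number a stronger inhibitor), compound 1 `COC(=O)C1=C(C)NC(=O)NC1c1ccc(OC)cc1` gives 59200 nM, and compound 2 `COC(=O)C1=C(C)NC(=O)NC1c1ccccc1OC` gives 59200 nM. Compound 3 `COC(=O)C1=C(C)NC(=O)NC1c1ccc(OC)c(OC)c1`, which carries two methoxy groups, is reported in this assay as "not active" (no number reported), so no single number stands for compound 3 and its place among the three can only be described as lacking a measured potency. Compound 4 `COC(=O)C1=C(C)NC(=O)NC1c1ccc(F)c(OC)c1` differs from compound 3 by fluoro in place of methoxy on an aromatic carbon. Among the measured compounds shown here, no measured pair of compounds shows this change, so the size of the step in this assay is not known from the data; given that compound 3 has no number and that both compound 1 and compound 2 sit at the weak end, any step is expected to be small, within the scatter, with no clear direction. Compound 4 is therefore expected to give roughly 90000 nM in this assay, with a range from 30000 nM to 300000 nM, because compound 1 gives 59200 nM and the weak level of that value suggests that compound 4 will fall in the same region.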

Compound 4, half-maximal inhibitory concentration: 22100 nM
Beside the measured number, compound 4's estimate is 4.1-fold (0.61 log units) above it, and the stated range ends above it.
By their numbers in this assay, from the lowest: compound 4; then compounds 1 and 2 (each within the scatter of the next).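

In this assay, among the compounds shown here, compound 3 is reported as not active, with no number, so no step from it to compound 4 can be read. The compounds shown leave open what fluoro in place of methoxy on an aromatic carbon does to potency. Nothing shown bears on a cause for this result.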